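Indole carboxamide piperazinone series: cytotoxicity notes

This account rests on a few compounds, and the source may have more. Where it says the series, first, only, none or still open, it means among the compounds named here.

Measured compounds:
compound 1 `COc1ccc2[nH]c(C(=O)N3CC(=O)N(Cc4ccccc4)[C@@H](CN4CCCCC4)C3)cc2c1` — 76900 nM
compound 2 `COc1ccc2[nH]c(C(=O)N3CC(=O)N(Cc4cccc(OC)n4)[C@@H](Cc4ccccc4)C3)cc2c1` — > 30000 nM

Within the data shown here, in an ADME assay on Vero cells (Chlorocebus sabaeus) for cytotoxicity, with a stated time of 7 days (on this read-out lower numbers stand for higher toxicity in this test and higher numbers for lower toxicity in this test), compound 1 gives 76900 nM, the only numerical value in the set. Compound 2 reaches only a limit of the assay, > 30000 nM, and the limit of > 30000 nM in this assay, at which 1 of the 2 values shown sits, marks it. Among the measured compounds shown here, no step between measured compounds is available.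

Compound 3 `COc1ccc2[nH]c(C(=O)N3CC(=O)N(Cc4ccccc4)[C@@H](CN4C(=O)c5ccccc5C4=O)C3)cc2c1` is not yet measured. Relative to compound 1 it carries a group of 11 heavy atoms (8 carbon, 1 nitrogen, 2 oxygen; one five-membered non-aromatic ring with 1 hetero atom, one six-membered aromatic ring of carbon only) in place of a group of 6 heavy atoms (5 carbon, 1 nitrogen; one six-membered non-aromatic ring with 1 hetero atom), on a saturated chain carbon bound to a saturated ring carbon. For the measured compounds named here, with no measured step to lean on, the step of a 1.3-fold lower number from compound 1 to compound 3 (0.11 log units; within the scatter) from compound 1 is expected to stay within the usual scatter, in no particular direction. Compound 3 is therefore estimated at 60000 nM, expected between 20000 nM and 150000 nM, with a fair chance that the assay reports only a limit.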

Compound 3, half-maximal cytotoxic concentration: 41000 nM
The estimate for compound 3 lay 1.5-fold (0.17 log units) above the measured number; low and high end bracket the measured number.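

Among these compounds, the exchange of piperidin-1-yl for the group of 11 heavy atoms, on a saturated chain carbon bound to a saturated ring carbon, gives a 1.9-fold lower number from compound 1 to compound 3 (0.27 log units; within the scatter) in this assay as the first readable step at this position. This place in the series therefore accepts a much larger group with two non-aromatic double bonds, and the read-out stays within the scatter. Nothing among the data shown accounts for the size of this step.

Going by these compounds, whether a carboxylic acid or a primary amine on the same chain carbon would move the read-out beyond the scatter remains open. A longer chain carrying piperidin-1-yl also remains untested among the compounds shown.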